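The source may report more compounds than this note shows. Statements on the series, on what has been measured and on what is new or still open speak of the compounds shown alone.

Measured compounds:
compound 1, `Clc1ccccc1NCc1nc2ccc(Br)cc2[nH]1`, gives 20%
compound 2, `Brc1ccc(NCc2nc3ccc(Br)cc3[nH]2)cc1`, gives 20%

Both compounds were tested in a functional assay on the whole organism (strain albino) for inhibition, with Rattus norvegicus as the target, read by paw edema, with a stated time of 60 min, at a dose of 100 mg/kg by the oral route; a higher number here means more inhibition at the dose given (going by the name of the read-out), a lower number less inhibition. Compound 1 gives 20% and compound 2 gives 20%, so compound 2 stands level with compound 1 at the digits shown; the two values lie within the scatter of each other, and nothing can be made of any difference between them.

The next compound is compound 3, `Cc1ccc(NCc2nc3ccc(Br)cc3[nH]2)cc1`. It differs from compound 2 in one place: methyl in place of bromo on an aromatic carbon. The shared core and the linker are kept unchanged.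

For the measured compounds named here, no step between two measured compounds is available here that would show how this assay answers to such a change. Going by the values given here, the only guide is that compound 1 and compound 2 give the same value in this assay, and on that basis no step beyond the scatter is expected from compound 2 to compound 3, either up or down. Compound 3 is therefore estimated to give 20%, with a range from 5% to 35%, which is an expected step of no change at the digits printed from compound 2 to compound 3 (within the scatter).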

Compound 3, a percentage reported as inhibition, in the whole organism at one dose (the size of the read-out at that dose, not a potency): 20%
Compound 3: the middle estimate sits on the measured number at the digits printed, within the range that was stated.
By their numbers in this assay, from the lowest: compounds 1, 2 and 3 (each within the scatter of the next).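

In this assay, for the compounds shown here, putting methyl in place of bromo on an aromatic carbon, para to a large group, gives no change at the digits printed from compound 2 to compound 3 (within the scatter) and is the only comparison here of two compounds that differ in one place. It shows that, at this position and this single oral dose, methyl and bromo cannot be told apart by the read-out, although the step says nothing about potency, since a reading at one dose is not a measure of that. Nothing available here explains this outcome.

The compounds shown leave open whether this position responds to any change at all, since both groups tried here are small, with a single heavy atom each, and neither adds a hydrogen-bond donor or acceptor. An amine, a carboxylic acid or a longer chain at the same place could test that, and could show whether the read-out moves clear of the scatter in either direction or stays level with compound 2 and compound 3.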